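The compounds below may be only part of what the source reports. "The series", "measured", "known", "first", "only" and "open" are said of these compounds alone.

Compound 1 `N#CC1=C(N)Oc2c(N)cc3nc4ccccc4nc3c2C12C(=O)N(Cc1cnnn1-c1ccc(Cl)cc1)c1ccccc12` gives > 50000 nM.
Compound 2 `N#CC1=C(N)Oc2c(N)cc3nc4ccccc4nc3c2C12C(=O)N(Cc1cnnn1-c1cccc(C(F)(F)F)c1)c1ccccc12` gives 5400 nM.
Compound 3 `CCOc1ccccc1-n1nncc1CN1C(=O)C2(C(C#N)=C(N)Oc3c(N)cc4nc5ccccc5nc4c32)c2ccccc21` gives > 50000 nM.

In a functional assay on A549 cells (Homo sapiens) for antiproliferative activity, read by MTT assay, with a stated time of 48 h (on this read-out higher numbers stand for weaker inhibition and lower numbers for stronger inhibition), compound 3 reaches only a limit of the assay, not a number. Compound 3 thus sits at the limit of > 50000 nM in this assay, at which 2 of the 3 values shown sit. Compound 4 `Cc1ccc(-n2nncc2CN2C(=O)C3(C(C#N)=C(N)Oc4c(N)cc5nc6ccccc6nc5c43)c3ccccc32)cc1C` differs from it in one place: 3,4-dimethylphenyl in place of 2-ethoxyphenyl on an aromatic nitrogen. Among the compounds with values here, two measured steps touch the 2-ethoxyphenyl group: an at least 9.2-fold higher number from compound 2 to compound 3 (0.96 log units; beyond the scatter) and a step that the two limits leave unreadable from compound 1 to compound 3. Neither measured step puts a 3,4-dimethylphenyl group on this aromatic nitrogen, and a step starting from a limit cannot be read cleanly. The expectation for compound 4 is therefore a weak, uncertain signal, estimated at 30000 nM within 6000 nM to 60000 nM, which would mean an expected at least 1.6-fold lower number from compound 3 to compound 4 (0.22 log units; that floor lies within the scatter).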

Compound 4, half-maximal inhibitory concentration: > 50000 nM
Compound 4 gave a limit, no number; the forecaster's own chance of this, stated with the estimate: 55%; at least 1.6-fold (0.22 log units) between middle value and limit.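

Swapping the 3-(trifluoromethyl)phenyl group for 3,4-dimethylphenyl on this aromatic nitrogen gives an at least 9.2-fold higher number from compound 2 to compound 4 (0.96 log units; beyond the scatter), so the measurable activity of compound 2 does not carry over to this group. The steps linking compound 4 to compound 1 and compound 3 cannot be read: both ends of each are limits. In this assay, compound 2 is now the only compound with a number instead of a limit: the limit of > 50000 nM in this assay, at which 3 of the 4 values shown sit.

Going by these compounds, it stays open whether the trifluoromethyl group or its place on the phenyl ring accounts for the number of compound 2. On these data alone, how an unsubstituted phenyl ring, or one bearing an amine or a carboxylic acid, would read also stays open.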